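Replacing the second sulfonyl with a diethylcarbamoyl

The source may hold more compounds than are shown below. What is called first, only, known or untested is meant among the compounds shown, and "the series" means these compounds.

Compound 2 `O=C([C@@H]1CCCN(S(=O)(=O)c2ccc(S(=O)(=O)C3COC3)cc2)C1)N1CCC(F)(F)CC1` gives 361 nM in a functional assay on BXPC-3 cells (Homo sapiens) for inhibition, read by MTT assay, with a stated time of 7 days (a higher number here means a weaker inhibitor, a lower number a stronger inhibitor), and stands second highest among the three measured values. For the measured compounds named here, compound 1 `O=C([C@@H]1CCCN(S(=O)(=O)c2ccc(S(=O)(=O)N3CC[C@@H](O)C3)cc2)C1)N1CCC(F)(F)CC1` gives 330 nM, and the step of a 1.1-fold higher number from compound 1 to compound 2 (0.04 log units; within the scatter) is the only one-place change measured. Compound 3 `CCN(CC)S(=O)(=O)c1ccc(S(=O)(=O)N2CCC[C@@H](C(=O)NC3CCOCC3)C2)cc1` gives 8570 nM; it differs from compound 2 in two places, so its gap is not attributed to either. Compound 4 `CCN(CC)C(=O)c1ccc(S(=O)(=O)N2CCC[C@@H](C(=O)N3CCC(F)(F)CC3)C2)cc1` carries the change (diethylcarbamoyl in place of (oxetan-3-yl)sulfonyl on an aromatic carbon). Going by the values given here, the one measured step kept the sulfonyl and was flat, so it bears only loosely on removing it; compound 3 hints at weaker numbers with a diethyl group there, but confounded. A moderately higher number is expected, a 2.5-fold higher number from compound 2 to compound 4 (0.40 log units; beyond the scatter). Compound 4 is estimated at 900 nM, range 250 nM to 3500 nM.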

Compound 4, half-maximal inhibitory concentration: 240 nM
Beside the measured number, compound 4's estimate is 3.8-fold (0.57 log units) above it, outside the stated range (below it).
By their numbers in this assay, from the lowest: compounds 4, 1 and 2 (each within the scatter of the next); then compound 3.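

In this assay, a sulfonyl link on this aromatic carbon proves not to be required: the ring-free diethylcarbamoyl group gives a 1.5-fold lower number from compound 2 to compound 4 (0.18 log units; within the scatter) and a 1.4-fold lower number from compound 1 to compound 4 (0.14 log units; within the scatter). The position therefore accepts a wider change than the sulfonyl-to-sulfonyl step could show, with compounds 1, 2 and 4 not separated. Nothing at hand offers a reason for this flat response.

Still open, going by these compounds, is whether any group at this position moves the number beyond the scatter. A carboxylic acid or a nitrile in place of the diethylcarbamoyl would test this.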